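The source may hold more compounds than are shown below. What is called first, only, known or untested is meant among the compounds shown, and "the series" means these compounds.

Compound 3 `Cc1cc(C)c(SCc2ncnc3c2ncn3[C@@H]2O[C@H](CO)[C@@H](O)[C@H]2O)c(C)c1`: 33100 nM
Compound 2 `Cc1ccc(CSc2ncnc3c2ncn3[C@@H]2O[C@H](CO)[C@@H](O)[C@H]2O)cc1`: 457 nM
Compound 1 `OC[C@H]1O[C@@H](n2cnc3c(SC4CCCCC4)ncnc32)[C@H](O)[C@@H]1O`: 6310 nM

In an assay on isolated protein for binding affinity to Equilibrative nucleoside transporter 1 (Homo sapiens) (a higher number here means a weaker inhibitor, a lower number a stronger inhibitor), compound 3 gives the highest number of the three, so it is the weakest inhibitor here; compound 1 sits closest to it and compound 2 furthest away, with the strongest binding. Compound 4 `OC[C@H]1O[C@@H](n2cnc3c(CSc4ccccc4Br)ncnc32)[C@H](O)[C@@H]1O` differs from compound 3 in one place: 2-bromophenyl in place of 2,4,6-trimethylphenyl on a sulfur. Going by the values given here, the only measured step that changes the group on the sulfur is a 14-fold lower number from compound 1 to compound 2 (1.14 log units; beyond the scatter), which shows that swapping this group can move the number a lot, though that pair keeps the sulfur on the core rather than on a chain carbon. The smaller bromophenyl is therefore expected to give a moderately lower number, a 4.1-fold lower number from compound 3 to compound 4 (0.62 log units; beyond the scatter), and compound 4 is estimated at 8000 nM, within 1500 nM to 40000 nM.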

Compound 4, half-maximal inhibitory concentration: 2400 nM
Beside the measured number, compound 4's estimate is 3.3-fold (0.52 log units) above it; the measured number falls inside the stated range.
By their numbers in this assay, from the lowest: compound 2; then compound 4; then compound 1; then compound 3.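

On a sulfur whose other neighbour is a saturated chain carbon, the aryl group alone can matter greatly in this assay: 2-bromophenyl in place of 2,4,6-trimethylphenyl gives a 14-fold lower number from compound 3 to compound 4 (1.14 log units; beyond the scatter). On the aromatic carbon, ((2-bromophenyl)sulfanyl)methyl still trails (4-methylbenzyl)sulfanyl, with a 5.3-fold higher number from compound 2 to compound 4 (0.72 log units; beyond the scatter), but improves on cyclohexylsulfanyl, with a 2.6-fold lower number from compound 1 to compound 4 (0.42 log units; beyond the scatter).

No supporting evidence is available to explain these shifts. From the compounds shown here alone, whether a plain phenyl or a 2-chlorophenyl on that same sulfur would give a similar number remains open, so the part played by the bromine is unsettled.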